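Chloro addition on the urea aryl ring of compound 3

The source may report more compounds than this note shows. Statements on the series, on what has been measured and on what is new or still open speak of the compounds shown alone.

Three members of the series have been run in a functional assay on MGC-803 cells (Homo sapiens) for antiproliferative activity, read by MTT assay, with a stated time of 48 h; a higher number here means a weaker inhibitor, a lower number a stronger inhibitor. Compound 1 `O=C(Nc1ccccc1)Nc1cccc(CNc2nccnc2Cl)c1` gives 16300 nM. Compound 2 `O=C(Nc1cccc(Cl)c1)Nc1cccc(CNc2nccnc2Cl)c1` gives 5330 nM; the change from compound 1 is chloro in place of hydrogen on an aromatic carbon and the step is a 3.1-fold lower number from compound 1 to compound 2 (0.49 log units; beyond the scatter). Compound 3 `Cc1ccc(NC(=O)Nc2cccc(CNc3nccnc3Cl)c2)cc1` gives 11900 nM; the change from compound 1 is methyl in place of hydrogen on an aromatic carbon and the step, a 1.4-fold lower number from compound 1 to compound 3 (0.14 log units; within the scatter), stays within the scatter. Between compound 2 and compound 3 the step is a 2.2-fold higher number from compound 2 to compound 3 (0.35 log units; beyond the scatter).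

Compound 4 `Cc1ccc(NC(=O)Nc2cccc(CNc3nccnc3Cl)c2)cc1Cl` has not been measured. Its difference from compound 3 is chloro in place of hydrogen on an aromatic carbon. This is the same kind of change as that between compound 1 and compound 2, seen twice in the set: in both cases chloro enters on an aromatic carbon of a six-membered aromatic ring of carbon only, meta to a large group; in compound 4 the entering chloro is in addition ortho to a methyl group (1 heavy atom), which is absent around the place in compound 2. The cores of the two pairs differ by the change read under the difference between compound 1 and compound 3.

For the measured compounds named here, because the only measured step of this kind, a 3.1-fold lower number from compound 1 to compound 2 (0.49 log units; beyond the scatter), is modest and beyond the scatter, compound 4 is expected to move by a step of about a 2.6-fold lower number from compound 3 to compound 4 (0.42 log units; beyond the scatter) in this assay. The estimated value for compound 4 in this assay is 4500 nM, with a range from 2000 nM to 10000 nM.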

Compound 4, half-maximal inhibitory concentration: 17500 nM
Compound 4: middle estimate off by 3.9-fold (0.59 log units), on the low side; measured number outside the range, above it.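

In this assay, chloro in place of hydrogen gives a 1.5-fold higher number from compound 3 to compound 4 (0.17 log units; within the scatter), so the lower number seen with this change on the core of compound 1 does not carry over to the core of compound 3: the same change on two cores in this assay, a 3.1-fold lower number (0.49 log units; beyond the scatter) from compound 1 to compound 2 and a 1.5-fold higher number (0.17 log units; within the scatter) from compound 3 to compound 4, 4.5-fold (0.65 log units) apart, beyond the scatter of two such steps Read along the other edge of the same set, methyl in place of hydrogen gives a 3.3-fold higher number from compound 2 to compound 4 (0.52 log units; beyond the scatter), which sets the 3-chloro-4-methylphenyl urea apart from the 3-chlorophenyl urea, while the same change on the core of compound 1 stays within the scatter: the same change on two cores in this assay, a 1.4-fold lower number (0.14 log units; within the scatter) from compound 1 to compound 3 and a 3.3-fold higher number (0.52 log units; beyond the scatter) from compound 2 to compound 4, 4.5-fold (0.65 log units) apart, beyond the scatter of two such steps With both groups present, a 1.1-fold higher number from compound 1 to compound 4 (0.03 log units; within the scatter) also stays within the scatter, so across these four compounds the chloro and methyl steps do not add, although a single set of four compounds in one cell line gives no cause for this and says nothing about the same change on any other core.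

The compounds shown leave open whether the chloro step also fails to carry over when methoxy or trifluoromethyl replaces the methyl group. As far as these compounds go, it also remains open how the series responds to an amine or a carboxylic acid on the urea aryl ring.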